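The source may hold more compounds than are shown below. What is called first, only, known or untested is meant among the compounds shown, and "the series" means these compounds.

Measured so far in an assay on Cerebral cortex for binding affinity to adenosine receptor A1 (Cavia porcellus), read by radioligand binding; a higher number here means a weaker inhibitor, a lower number a stronger inhibitor:
Compound 1 `CCCn1c(=O)n(CCCN(C)C)c(=O)c2[nH]cnc21` gives 43200 nM.
Compound 2 `CCCn1c(=O)n(CCO)c(=O)c2[nH]cnc21` gives 50000 nM.
Compound 3 `CCCn1c(=O)n(C)c(=O)c2c1ncn2CCCN(C)C` gives only a limit of the assay, > 200000 nM.

Compound 1 and compound 2 share a core and differ in one place (hydroxy in place of (dimethylamino)methyl on a saturated chain carbon, two bonds along the chain from an aromatic nitrogen). In this assay that change made a step of a 1.2-fold higher number from compound 1 to compound 2 (0.06 log units; within the scatter). The core of compound 3 differs from the core of compound 1 in more than one place; that difference is not broken down here. Compound 4 `CCCn1c(=O)n(C)c(=O)c2c1ncn2CCO` is not yet measured; it stands to compound 3 as compound 2 stands to compound 1 (hydroxy in place of (dimethylamino)methyl on a saturated chain carbon, two bonds along the chain from an aromatic nitrogen). The value of compound 3 is a limit (the limit of > 200000 nM in this assay, at which 1 of the 3 values shown sits). For compound 4 a step that the limit leaves unreadable from compound 3 to compound 4 is expected, resting on the step from compound 1 to compound 2 a 1.2-fold higher number from compound 1 to compound 2 (0.06 log units; within the scatter) having stayed within the scatter. Compound 4 is therefore estimated at 250000 nM, between 90000 nM and 700000 nM.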

Compound 4, inhibition constant: 41400 nM
For compound 4 the middle estimate is 6.0-fold (0.78 log units) above the measured one, and the stated range ends above it.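

In this assay, hydroxy in place of (dimethylamino)methyl gave an at least 4.8-fold lower number from compound 3 to compound 4 (0.68 log units; beyond the scatter). The step seen on one core therefore did not carry over to the other: the same change on two cores in this assay, a 1.2-fold higher number (0.06 log units; within the scatter) from compound 1 to compound 2 and an at least 4.8-fold lower number (0.68 log units; beyond the scatter) from compound 3 to compound 4, at least 5.5-fold (0.74 log units) apart, beyond the scatter of two such steps

This does not show why the two cores differ, or how large the step on the second core truly is, since the value of compound 3 is only a limit of the assay: the limit of > 200000 nM in this assay, at which 1 of the 4 values shown sits.

On these data alone, it remains open how other groups at this place, such as a carboxylic acid or a primary amine, would behave on these two cores. A third core could follow either step or neither.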